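Trifluoromethoxy in Place of Fluoro on Compound 1

This account rests on a few compounds, and the source may have more. Where it says the series, first, only, none or still open, it means among the compounds named here.

Compound 1 `Cc1cc(NC(=O)Nc2cccc(F)c2)c2ccccc2n1` is the starting point in an ADME assay on HepG2 cells (Homo sapiens) for cytotoxicity, with a stated time of 72 h; a higher number here means that more compound is needed for the effect, a lower number that less compound is needed. Compound 1 gives > 25000 nM, which is a limit and not a number. Compound 2 `Cc1cc(NC(=O)Nc2ccc(O)cc2)c2ccccc2n1` gives > 25000 nM, also a limit. Compound 3 `Cc1cc(NC(=O)Nc2ccc(N)cc2)c2ccccc2n1` gives > 25000 nM, again a limit. The whole set therefore rests on (the limit of > 25000 nM in this assay, at which 3 of the 3 values shown sit). Compound 4 `Cc1cc(NC(=O)Nc2cccc(OC(F)(F)F)c2)c2ccccc2n1` carries trifluoromethoxy in place of fluoro on an aromatic carbon, (trifluoromethoxy in place of fluoro on an aromatic carbon). The nearest guides are a step that the two limits leave unreadable from compound 1 to compound 2 and a step that the two limits leave unreadable from compound 1 to compound 3, and neither has a size. With only these to go on, no step beyond the scatter is expected in this assay. The expected step is a number no higher from compound 1 to compound 4 (the limit leaves the size open). For compound 4 the estimate is 25000 nM, with an expected range of 10000 nM to 50000 nM.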

Compound 4, half-maximal effective concentration: 13000 nM
Compound 4: middle estimate off by 1.9-fold (0.28 log units), on the high side, and the stated range covers the measured number.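

In this assay, among these compounds, trifluoromethoxy in place of fluoro on this aromatic carbon gives the only value shown that is a number and not a limit, with an at least 1.9-fold lower number from compound 1 to compound 4 (0.28 log units; that floor lies within the scatter). Among the compounds shown here, the earlier steps cannot be read, so this is the only step with any size, and its floor does not go beyond the scatter. The other values offer no number to compare with: the limit of > 25000 nM in this assay, at which 3 of the 4 values shown sit.

On these data alone, the true size of the step stays open, since compound 1 has only a limit. Also open, as far as these compounds go, is how methoxy or a carboxylic acid would read on this aromatic carbon.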